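A few compounds are considered here, and "the series" means these few. Any claim that something is new, unique, unknown or untested is made for them only; others in the source may bear on it.

Values in an ADME assay on MOLT-3 cells (Homo sapiens) for cytotoxicity, with a stated time of 7 days (a lower number here means that less compound is tolerated, a higher number that more compound is tolerated), for the series:
compound 1 `C=CCOc1nc(N)nc2c1ncn2/C=C1/CC1(CO)CO` gives > 20000 nM
compound 2 `Nc1nc(NC2CC2)c2ncn(/C=C3/CC3(CO)CO)c2n1` gives > 20000 nM
compound 3 `Nc1nc(N2CCCC2)c2ncn(/C=C3/CC3(CO)CO)c2n1` gives "not determined" (no result reported)

The entries for compound 1 and compound 2 are limits of the assay, not numbers. Compound 3 has no number to start from, so the only reference point is the limit of > 20000 nM in this assay, at which 2 of the 3 values shown sit.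

The step to compound 4 `CCCCCOc1nc(N)nc2c1ncn2/C=C1/CC1(CO)CO` is pentyloxy in place of pyrrolidin-1-yl on an aromatic carbon, in words pentyloxy in place of pyrrolidin-1-yl on an aromatic carbon. Going by the values given here, the one measured step that bears on it is a step that the two limits leave unreadable from compound 1 to compound 2, which exchanges an oxygen-linked group for a nitrogen-linked one at that carbon. It gives no size to carry over, so no size or direction can be assigned to the change from compound 3 in this assay.

Compound 4 shares an oxygen-linked group with compound 1, which gives > 20000 nM, again a limit. A report at that same limit is therefore the likeliest outcome for compound 4, with some chance of a number a little lower. For compound 4 the expected value is 20000 nM, with an estimated range from 8000 nM to 40000 nM.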

Compound 4, half-maximal cytotoxic concentration: > 20000 nM
Compound 4 was reported as a limit; the forecaster's own chance of this, stated with the estimate: 70%; the middle value lies on the limit itself.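

Compound 4 gives > 20000 nM in this assay, a limit and not a number, so the steps linking compound 1, compound 2 and compound 4 cannot be read. The compounds shown leave open whether allyloxy, cyclopropylamino and pentyloxy on this aromatic carbon differ at all in this assay.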